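Aryl amine in place of butylamine on a shared biphenyloxymethyl series

A few compounds are considered here, and "the series" means these few. Any claim that something is new, unique, unknown or untested is made for them only; others in the source may bear on it.

Working notes on two measured compounds and one still to be measured, all carrying the same biphenyloxymethyl arm. Compound 1 `COc1ccc2cc(C(C)c3nnc(COc4ccc(-c5ccccc5)cc4)o3)ccc2c1` and compound 2 `CCCCNc1nnc(COc2ccc(-c3ccccc3)cc2)s1` were tested in a functional assay on the whole organism (strain Wistar) for inhibition, with Rattus norvegicus as the target, read by paw edema, with a stated time of 4 h, at a dose of 10 mg/kg by the oral route; a higher number here means more inhibition at the dose given (going by the name of the read-out), a lower number less inhibition. In this assay, going by the values given here, compound 2 gives 27.3%, and compound 1 gives 25%; these two values lie within the usual scatter of each other, so the numbers so far do not separate the two compounds.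

Compound 3 `Cc1ccc(Nc2nnc(COc3ccc(-c4ccccc4)cc3)s2)c(C)c1` is the next candidate. It differs from compound 2 in one place: 2,4-dimethylphenyl in place of butyl on a nitrogen on an aromatic ring. Cut one bond further out, the change reads butylamino to (2,4-dimethylphenyl)amino. Among the compounds with values here, no measured pair shows the effect of this exchange, so nothing in the data points in either direction.

With that in mind, compound 3 is expected to land near compound 2 in this assay, and the expected step of a number 2.7 percentage points higher from compound 2 to compound 3 (within the scatter) is one that stays within the scatter. The estimate for compound 3 is 30%, with a range of 15% to 48%.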

Compound 3, a percentage reported as inhibition, in the whole organism at one dose (the size of the read-out at that dose, not a potency): 56.8%
For compound 3 the middle estimate is 26.8 percentage points below the measured one, and the stated range ends below it.
By their numbers in this assay, from the lowest: compounds 1 and 2 (each within the scatter of the next); then compound 3.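

In this assay, going by these compounds alone, exchanging butyl for 2,4-dimethylphenyl on a nitrogen on an aromatic ring gives the only step beyond the scatter so far, a number 29.5 percentage points higher from compound 2 to compound 3 (beyond the scatter), and it is not a small one for this read-out. This position therefore responds to the group it carries, which the earlier values, lying within the scatter of each other, could not show. Nothing measured here accounts for the size of this step.

Going by these compounds, it remains open whether the gain depends on the aromatic ring itself or on its two methyl groups; plain phenyl and cyclohexyl on the same nitrogen would separate the two. As the read-out comes from one oral dose, it also leaves open how the compounds compare across doses.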